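The source may hold more compounds than are shown below. What is called first, only, known or untested is meant among the compounds shown, and "the series" means these compounds.

Three chlorinated quinones have been measured in a functional assay on SNO cells (Homo sapiens) for cytotoxicity, read by XTT assay, with a stated time of 24 h; on this read-out lower numbers stand for stronger inhibition and higher numbers for weaker inhibition: compound 1 (`COc1c(C)cc(Cl)c2c1C(=O)C=CC2=O`) gives 44900 nM, compound 2 (`CC(=O)Oc1cc(C)c(Cl)c2c1C(=O)C=CC2=O`) gives 28800 nM and compound 3 (`COc1cc(C)c(Cl)c2c1C(=O)C=CC2=O`) gives 24600 nM. Compound 3 therefore has no clear standing of its own, since its value lies within the scatter of the values of both other compounds. The next compound is compound 4 (`Cc1cc(O)c2c(c1Cl)C(=O)C=CC2=O`), which carries hydrogen in place of methyl on an oxygen on an aromatic ring, so that methoxy becomes hydroxy: hydrogen in place of methyl on an oxygen on an aromatic ring.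

Going by the values given here, only one measured step bears directly on this oxygen. It is the exchange of acetyl for methyl, a 1.2-fold lower number from compound 2 to compound 3 (0.07 log units; within the scatter), and it stays within the scatter. That step shows that these two groups on the oxygen are not told apart in this assay. Among the compounds with values here, none of the measured compounds carries the free hydroxy, however, so the data cannot rule out a larger move. On this limited evidence, no step beyond the scatter is expected, and no direction can be favoured with confidence. The estimated step is a 1.4-fold lower number from compound 3 to compound 4 (0.14 log units; within the scatter). For compound 4 the expected value is 18000 nM, with an estimated range from 6000 nM to 45000 nM.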

Compound 4, half-maximal inhibitory concentration: 17200 nM
Compound 4: middle estimate off by 1.0-fold (0.02 log units), on the high side; the measured number falls inside the stated range.
By their numbers in this assay, from the lowest: compounds 4, 3, 2 and 1 (each within the scatter of the next, the first and the last beyond it).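

With the free hydroxy in place, three groups on this oxygen on an aromatic ring can now be compared in this assay, where hydrogen in place of methyl gives a 1.4-fold lower number from compound 3 to compound 4 (0.16 log units; within the scatter) and hydrogen in place of acetyl gives a 1.7-fold lower number from compound 2 to compound 4 (0.22 log units; within the scatter). Going by these compounds alone, the earlier step had compared only two groups that cap the oxygen, whereas these two steps show that uncapping it, whether from methoxy or from the acetyl ester, also stays within the scatter, so methyl, acetyl and hydrogen are not told apart here. Nothing available explains why this read-out stays so insensitive to the change at this oxygen.

The compounds shown leave open whether this tolerance extends to larger groups on the oxygen, such as a benzyl group or a longer chain, or to an amine in place of the hydroxy. They also leave open whether the three groups would remain indistinguishable if the chlorine on the shared core gave way to another halogen such as bromine.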